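Cyanophenyl for fluorophenyl on a pyrazole carboxylic acid

The compounds below may be only part of what the source reports. "The series", "measured", "known", "first", "only" and "open" are said of these compounds alone.

Measured compounds:
Compound 1 `Cc1n[nH]c(C(=O)O)c1Cc1ccc2ccccc2n1`: 1700 nM
Compound 2 `Cc1n[nH]c(C(=O)O)c1Cc1cccc(-c2cccc(F)c2)c1`: 500 nM
Compound 3 `Cc1n[nH]c(C(N)=O)c1Cc1cccc(-c2ccc(F)cc2)c1`: 1400 nM

Of the compounds shown here, three sharing the same core have been tested in an assay on isolated protein for inhibition of 2-Hydroxyacid oxidase 2 (Rattus norvegicus); on this read-out higher numbers stand for weaker inhibition and lower numbers for stronger inhibition. Compound 1 gives 1700 nM. Compound 2, which carries a 3-fluorophenyl on the aromatic ring, gives 500 nM in this assay. Compound 3, with an amide in place of the acid and a 4-fluorophenyl, gives 1400 nM. Compound 2 has the lowest number of the three; its nearest neighbour is compound 3, and its furthest is compound 1, both beyond the usual scatter. No pair among these three differs in one place only, so no single step can be read from them.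

The unmeasured compound 4 `Cc1n[nH]c(C(=O)O)c1Cc1cccc(-c2ccc(C#N)cc2)c1` is reached from compound 2 by one change: 4-cyanophenyl in place of 3-fluorophenyl on an aromatic carbon. The new group sits on an aromatic carbon, meta to a large group, where the 3-fluorophenyl stood before.

For the measured compounds named here, with no measured step of this kind to lean on, the expectation is a small step in this assay, if any, leaning toward a somewhat higher number; the step from compound 2 to compound 4 is estimated at a 1.4-fold higher number from compound 2 to compound 4 (0.15 log units; within the scatter). Compound 4 is therefore expected to give about 700 nM in this assay, within a range from 250 nM to 2000 nM.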

Compound 4, half-maximal inhibitory concentration: 300 nM
Estimate against measurement, compound 4: 2.3-fold (0.37 log units) above, and the stated range covers the measured number.
By their numbers in this assay, from the lowest: compounds 4 and 2 (each within the scatter of the next); then compounds 3 and 1 (each within the scatter of the next).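

In this assay, for the compounds shown here, replacing the 3-fluorophenyl with 4-cyanophenyl on an aromatic carbon, meta to a large group, gives a 1.7-fold lower number from compound 2 to compound 4 (0.22 log units; within the scatter), the first step in this set that can be read in one place, and it lies within the usual scatter. On this read-out the position therefore accepts a 4-cyanophenyl, with its nitrile and the hydrogen-bond acceptor counted with it, as readily as a 3-fluorophenyl, and the two carboxylic acids cannot be told apart. The step changes both the substituent and where it stands on the phenyl ring, so it cannot assign any share to either, and no supporting data bear on why the two acids read alike.

From the compounds shown here alone, what remains open is how a 3-cyanophenyl, a 4-fluorophenyl or a 4-aminophenyl would read on the same carboxylic acid, which would separate the identity of the substituent from its placement. Going by these compounds, it is also open whether a primary amide in place of the carboxylic acid would read the same with the 4-cyanophenyl in place.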